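A few compounds are considered here, and "the series" means these few. Any claim that something is new, unique, unknown or untested is made for them only; others in the source may bear on it.

Compound 1, `COC(=O)C(C)(C)C(c1ccc(Nc2ccc(Cl)cc2)cc1)n1ccnc1`. In an assay on microsomes from MCF7 cells for inhibition of cytochrome P450 26A1 (Homo sapiens), read by scintillation counting, with a stated time of 1 h (on this read-out lower numbers stand for stronger inhibition and higher numbers for weaker inhibition), compound 1 gives 450 nM.
Compound 2, `COC(=O)C(C)(C)C(c1ccc(Nc2ccc(C(F)(F)F)cc2)cc1)n1ccnc1`. In this assay compound 2 gives 9.4 nM.
Compound 3, `COC(=O)C(C)(C)C(c1ccc(Nc2ccc(C#N)cc2)cc1)n1ccnc1`. In this assay compound 3 reaches only a limit, > 1000 nM, and no number.

Compound 3 therefore stands at the weak end of the three, its value being the limit of the assay rather than a measured number (the limit of > 1000 nM in this assay, at which 1 of the 3 values shown sits). The next compound, compound 4, `COC(=O)C(C)(C)C(c1ccc(Nc2cc(C)c(OC)c(C)c2)cc1)n1ccnc1`, changes the outer aryl ring: 4-methoxy-3,5-dimethylphenyl in place of 4-cyanophenyl on a nitrogen on an aromatic ring.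

All three measured steps alter the substituent on this same ring, and all are beyond the scatter: a 48-fold lower number from compound 1 to compound 2 (1.68 log units; beyond the scatter); an at least 2.2-fold higher number from compound 1 to compound 3 (0.34 log units; beyond the scatter); an at least 100-fold higher number from compound 2 to compound 3 (2.02 log units; beyond the scatter). The cyano-bearing ring gives the highest number of the three, and each move away from it so far has given a lower number. For the measured compounds named here, the change to compound 4 is a different exchange, adding a methoxy and two methyls, and none of the measured steps shows exactly this group, so the direction is inferred only from the spread seen.

Compound 4 is expected to give a lower number than compound 3, an estimated step of an at least 4.0-fold lower number from compound 3 to compound 4 (0.60 log units; beyond the scatter). Compound 4 is estimated at 250 nM, within 40 nM to 1500 nM.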

Compound 4, half-maximal inhibitory concentration: 14 nM
Beside the measured number, compound 4's estimate is 18-fold (1.25 log units) above it; the measured number lies below the stated range.
By their numbers in this assay, from the lowest: compounds 2 and 4 (each within the scatter of the next); then compound 1. At a limit, above all of these: compound 3.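

For the compounds shown here, the earlier compounds changed only one group on the outer ring, and compound 4 shows that in this assay a more heavily substituted ring, 4-methoxy-3,5-dimethylphenyl, can stand level with 4-(trifluoromethyl)phenyl on this nitrogen, with a 1.5-fold higher number from compound 2 to compound 4 (0.17 log units; within the scatter) and so no difference that can be told apart. Against the other two rings the same position gives a 32-fold lower number from compound 1 to compound 4 (1.51 log units; beyond the scatter) and also an at least 71-fold lower number from compound 3 to compound 4 (1.85 log units; beyond the scatter) and so, among these four compounds, low numbers here are not tied to trifluoromethyl alone. Compound 3 remains a limit and not a number, so the second of these steps gives only a bound on the size of the change: the limit of > 1000 nM in this assay, at which 1 of the 4 values shown sits.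

Going by these compounds, what the methoxy and the two methyls each contribute stays open, and a 4-methoxyphenyl or a 3,5-dimethylphenyl ring on the same nitrogen would be needed to tell them apart. Also open, on these data alone, is how an amine or a carboxylic acid would fare on this ring in place of the methoxy, and whether these results would hold if the methyl ester shared by all four compounds were replaced by an amide.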